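Branched alkyl to 3-methyl-1-phenylbutyl on the ring nitrogen

The compounds below may be only part of what the source reports. "The series", "measured", "known", "first", "only" and "open" are said of these compounds alone.

Two compounds of the series have numbers. Compound 1 `CCCC(C(C)C)n1ccc2cc(/C(C)=C/C(=O)Nc3ccccc3OCCCC(=O)O)ccc21` gives 7.2 nM in an assay on Prostate gland for inhibition of steroid 5-alpha-reductase (Rattus norvegicus); a higher number here means a weaker inhibitor, a lower number a stronger inhibitor. Compound 2 `CCCCC(CC)n1ccc2cc(/C(C)=C/C(=O)Nc3ccccc3OCCCC(=O)O)ccc21` gives 7.1 nM in this assay, the lowest of the two numbers, though the step of a 1.0-fold lower number from compound 1 to compound 2 (0.01 log units; within the scatter) is within the scatter, so the two compounds are not distinguished by this assay.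

Compound 3 `C/C(=C\C(=O)Nc1ccccc1OCCCC(=O)O)c1ccc2c(ccn2C(CC(C)C)c2ccccc2)c1` differs from compound 2 by 3-methyl-1-phenylbutyl in place of 1-ethylpentyl on an aromatic nitrogen. Among the compounds with values here, the only measured step, a 1.0-fold lower number from compound 1 to compound 2 (0.01 log units; within the scatter), exchanges one branched seven-carbon chain for another and bears on this change only loosely; no measured step brings a ring into this position, so direction and size of the step are not anchored by data.

Compound 3 is therefore expected to give about 8 nM in this assay, with a range of 2.5 nM to 25 nM. The expected step from compound 2 to compound 3 is a 1.1-fold higher number from compound 2 to compound 3 (0.05 log units; within the scatter), which is essentially none beyond the scatter, with the wide range reflecting the untested entry of the ring.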

Compound 3, half-maximal inhibitory concentration: 6.3 nM
For compound 3 the middle estimate is 1.3-fold (0.10 log units) above the measured one; measured number inside the range.
By their numbers in this assay, from the lowest: compounds 3, 2 and 1 (each within the scatter of the next).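

On the aromatic nitrogen, 3-methyl-1-phenylbutyl in place of 1-ethylpentyl gives a 1.1-fold lower number from compound 2 to compound 3 (0.05 log units; within the scatter) in this assay, and in place of 1-isopropylbutyl it gives a 1.1-fold lower number from compound 1 to compound 3 (0.06 log units; within the scatter). The earlier compounds shown here compared only ring-free branched chains, whereas these steps show that a group carrying a six-membered aromatic ring of carbon only is accommodated here, with compounds 1, 2 and 3 not distinguished by this assay. No supporting measurement bears on why the ring leaves the number within the scatter.

The compounds shown leave open whether a plain benzyl group on this nitrogen would hold the same level, or whether the 3-methylbutyl part of the group is also needed. Also open, from the compounds shown here alone, is how a much shorter chain such as methyl, or an amine on the phenyl ring, would read in this assay.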